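A few compounds are considered here, and "the series" means these few. Any claim that something is new, unique, unknown or untested is made for them only; others in the source may bear on it.

Measured so far in a toxicity assay on J774.A1 cells (Mus musculus) for cytotoxicity, read by SYBR Green assay, with a stated time of 1 h; on this read-out lower numbers stand for an effect already at smaller amounts and higher numbers for an effect only at larger amounts of compound:
compound 1, `CN(C)c1ccc2cc(-c3ccccc3)c(N)nc2c1`, gives 4900 nM
compound 2, `CN(C)c1ccc2cc(-c3ccccc3F)c(N)nc2c1`, gives 1600 nM
compound 3, `CN(C)c1ccc2cc(-c3ccccn3)c(N)nc2c1`, gives 2200 nM

Two changes are charted. From compound 1 to compound 2 the change is fluoro in place of hydrogen on an aromatic carbon and the step is a 3.1-fold lower number from compound 1 to compound 2 (0.49 log units; beyond the scatter). From compound 1 to compound 3 the change is pyridin-2-yl in place of phenyl on an aromatic carbon and the step is a 2.2-fold lower number from compound 1 to compound 3 (0.35 log units; beyond the scatter). Compound 2 and compound 3 sit close together: a 1.4-fold higher number from compound 2 to compound 3 (0.14 log units; within the scatter).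

Compound 4, `CN(C)c1ccc2cc(-c3ncccc3F)c(N)nc2c1`, has not been measured. Relative to compound 3 the change is fluoro in place of hydrogen on an aromatic carbon, the same kind of change as that from compound 1 to compound 2, but the surroundings differ: in compound 2 the fluoro sits on a six-membered aromatic ring of carbon only, while in compound 4 it sits on a six-membered aromatic ring with 1 nitrogen, two atoms from the ring nitrogen. For the measured compounds named here, only one earlier example of this change exists, so the expected step from compound 3 to compound 4 in this assay, a 2.2-fold lower number from compound 3 to compound 4 (0.34 log units; beyond the scatter), is set a little smaller than the earlier one, resting on a 3.1-fold lower number from compound 1 to compound 2 (0.49 log units; beyond the scatter). For compound 4 the estimate is 1000 nM, expected between 400 nM and 2500 nM.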

Compound 4, half-maximal effective concentration: 16000 nM
Beside the measured number, compound 4's estimate is 16-fold (1.20 log units) below it, and the stated range ends below it.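

In this assay, fluoro in place of hydrogen gives a new step (a 7.3-fold higher number from compound 3 to compound 4 (0.86 log units; beyond the scatter)) that runs opposite to the earlier one, so on this evidence the change does not carry from the phenyl ring to the pyridin-2-yl ring: the same change on two cores in this assay, a 3.1-fold lower number (0.49 log units; beyond the scatter) from compound 1 to compound 2 and a 7.3-fold higher number (0.86 log units; beyond the scatter) from compound 3 to compound 4, 22-fold (1.35 log units) apart, beyond the scatter of two such steps
The other two steps to the new compound point the same way, with 3-fluoropyridin-2-yl in place of 2-fluorophenyl (a 10-fold higher number from compound 2 to compound 4 (1.00 log units; beyond the scatter)) and 3-fluoropyridin-2-yl in place of phenyl (a 3.3-fold higher number from compound 1 to compound 4 (0.51 log units; beyond the scatter)). This shows that the effect of the fluoro in this series depends on the ring that carries it, but with one pair per ring it gives no general rule and does not show what lies behind the reversal.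

Still open, going by these compounds, is whether chloro, methyl or methoxy in place of the fluoro would follow the same reversal on the pyridin-2-yl ring. Also open, on these data alone, is whether fluoro elsewhere on either ring would keep the direction seen here.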